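Series notes: pyridyl for furanyl on the shared core

The compounds below may be only part of what the source reports. "The series", "measured", "known", "first", "only" and "open" are said of these compounds alone.

Compound 1 `Oc1cccc(-c2cc(-c3ccc(Cl)cc3)nc(-c3cccnc3)c2)c1` and compound 2 `Oc1cccc(-c2cc(-c3ccc(Cl)cc3)nc(-c3ccco3)c2)c1` have both been measured in a functional assay on HCT-15 cells (Homo sapiens) for cytotoxicity, read by CCK-8 assay and cell counting, with a stated time of 2 days; a higher number here means a weaker inhibitor, a lower number a stronger inhibitor. In this assay compound 1 gives 16800 nM, and compound 2 gives 10200 nM. Going by the values given here, the only step measured so far, a 1.6-fold lower number from compound 1 to compound 2 (0.22 log units; within the scatter), exchanges furan-2-yl for pyridin-3-yl on an aromatic carbon and stays within the scatter, so compound 2 holds the lowest of the two numbers without being set apart from compound 1.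

Compound 3 `Oc1cccc(-c2cc(-c3ccncc3)nc(-c3ccc(Cl)cc3)c2)c1` is the next member of the series. Its change from compound 2 is pyridin-4-yl in place of furan-2-yl on an aromatic carbon. The step from compound 1 to compound 2 bears on this directly, since it is the same kind of swap between a five-membered and a six-membered aromatic ring at the same place, only run in the other direction and with the ring nitrogen in a different position; that step was within the scatter. On that basis no step beyond the scatter is expected in this assay, and the estimated step of a 1.4-fold higher number from compound 2 to compound 3 (0.14 log units; within the scatter) is small. Compound 3 is therefore expected to give about 14000 nM, with a range from 6000 nM to 35000 nM.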

Compound 3, half-maximal inhibitory concentration: 2630 nM
Compound 3: the middle estimate sits 5.3-fold (0.73 log units) above what was measured, and the stated range ends above it.
By their numbers in this assay, from the lowest: compound 3; then compounds 2 and 1 (each within the scatter of the next).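

In this assay the place next to the ring nitrogen of the shared core now shows that it responds to the group it carries: pyridin-4-yl brings a 3.9-fold lower number from compound 2 to compound 3 (0.59 log units; beyond the scatter) and also a 6.4-fold lower number from compound 1 to compound 3 (0.81 log units; beyond the scatter) and these steps stand apart from the earlier exchange of furan-2-yl for pyridin-3-yl, which stayed within the scatter. The step from the pyridin-3-yl compound is the more informative one, since both groups are six-membered aromatic rings with one nitrogen and differ only in where that nitrogen stands, so ring size alone does not order the series, and compound 3 holds the lowest number, set apart from both of the others. Nothing at hand bears on why the pyridin-4-yl group gives this result.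

Whether the number follows the place of the ring nitrogen remains open, as pyridin-2-yl and plain phenyl are not among the compounds shown, nor is a ring carrying an amine or a carboxylic acid. The compounds shown also vary this one position only, so it is open whether the same order would hold with the 3-hydroxyphenyl or 4-chlorophenyl group changed.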